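Carboxy added to the far phenyl of compound 2

The source may hold more compounds than are shown below. What is called first, only, known or untested is meant among the compounds shown, and "the series" means these compounds.

The study measures inhibition in an assay on microsomes from brain for inhibition of Fatty-acid amide hydrolase 1 (Rattus norvegicus), read by fluorescence and HPLC, with a stated time of 60 min; on this read-out lower numbers stand for stronger inhibition and higher numbers for weaker inhibition. Compound 1 `CCCCCCCCc1ccc(OC(C)C(=O)Cn2nnc(-c3ccccc3)n2)cc1` gives 24 nM, compound 2 `CC(Oc1ccc(Oc2ccc(F)cc2)cc1)C(=O)Cn1nnc(-c2ccccc2)n1` gives 24 nM, and compound 3 `CC(Oc1ccc(Oc2ccc(Cl)cc2)cc1)C(=O)Cn1nnc(-c2ccccc2)n1` gives 51 nM. Compound 2 thus stands level with compound 1 at the low end, while the change from fluoro to chloro makes a 2.1-fold higher number from compound 2 to compound 3 (0.33 log units; beyond the scatter). The other steps are no change at the digits printed from compound 1 to compound 2 (within the scatter) and a 2.1-fold higher number from compound 1 to compound 3 (0.33 log units; beyond the scatter). Compound 4 `CC(Oc1ccc(Oc2ccc(F)cc2)cc1)C(=O)Cn1nnc(-c2ccc(C(=O)O)cc2)n1` differs from compound 2 at the opposite end: carboxy in place of hydrogen on an aromatic carbon. Going by the values given here, none of the measured steps touches that phenyl, so the data give no direct guide, and the estimate for compound 4 in this assay is accordingly uncertain: 60 nM, within 15 nM to 300 nM, which would mean a 2.5-fold higher number from compound 2 to compound 4 (0.40 log units; beyond the scatter).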

Compound 4, half-maximal inhibitory concentration: 100 nM
Beside the measured number, compound 4's estimate is 1.7-fold (0.22 log units) below it; low and high end bracket the measured number.
By their numbers in this assay, from the lowest: compounds 1 and 2 (each within the scatter of the next); then compounds 3 and 4 (each within the scatter of the next).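

In this assay, going by these compounds alone, the far phenyl, which no earlier step touched, turns out to accept a carboxy group para to a large group at a modest cost: a 4.2-fold higher number from compound 2 to compound 4 (0.62 log units; beyond the scatter). Inhibition therefore survives a substantial addition at this end of the molecule, so this phenyl is not closed to change. No available measurement bears on the reason for the rise.

The compounds shown leave open whether the rise is specific to carboxy or would also follow from another group at this place, such as a methyl ester, an amide or an amine.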